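A few compounds are considered here, and "the series" means these few. Any claim that something is new, unique, unknown or untested is made for them only; others in the source may bear on it.

In a functional assay on the whole organism with Mus musculus as the target (on this read-out higher numbers stand for an effect only at larger amounts of compound and lower numbers for an effect already at smaller amounts), compound 3 `CNC(=O)[C@@H](CO)NCc1ccc(OCc2ccc(Cl)cc2)cc1` gives 216 mg/kg. That value lies within the scatter of compound 1 `CN(CC(N)=O)Cc1ccc(OCc2cccc(Cl)c2)cc1`, which gives 114 mg/kg. Compound 2 `C[C@@H](NCc1ccc(OCc2ccccc2)cc1)C(N)=O` gives 23.8 mg/kg, a lower number beyond the scatter of compound 3, so compound 3 sits at the end of the range that calls for larger amounts of compound.

The next compound, compound 4 `CNC(=O)[C@@H](CO)NCc1ccc(OCc2cccc(F)c2)cc1`, keeps the rest of compound 3 and changes one group: 3-fluorophenyl in place of 4-chlorophenyl on a saturated chain carbon bound to an oxygen on an aromatic ring. Thus 3-fluorophenyl stands in place of 4-chlorophenyl on a saturated chain carbon bound to an oxygen on an aromatic ring.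

Within the data shown here, no measured pair isolates this change, so any expectation rests on thin evidence. Compound 2, at 23.8 mg/kg, shows that a much smaller dose is possible among these compounds, but it differs from compound 3 in more than one place. A moderate move towards a lower number is therefore expected, and the estimated size is a 2.4-fold lower number from compound 3 to compound 4 (0.38 log units; beyond the scatter). For compound 4 the expected value is 90 mg/kg, with an estimated range of 30 mg/kg to 250 mg/kg.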

Compound 4, dose for half-maximal effect: 25.1 mg/kg
For compound 4 the middle estimate is 3.6-fold (0.55 log units) above the measured one; measured number outside the range, below it.
By their numbers in this assay, from the lowest: compounds 2 and 4 (each within the scatter of the next); then compounds 1 and 3 (each within the scatter of the next).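

In this assay, among these compounds, placing 3-fluorophenyl where 4-chlorophenyl stood on a saturated chain carbon bound to an oxygen on an aromatic ring gives an 8.6-fold lower number from compound 3 to compound 4 (0.93 log units; beyond the scatter) and is the only step here that isolates one change. It shows that, with the rest of compound 3 held fixed, this position alone can shift the read-out beyond the scatter, even though the heavy-atom count of the group and its count of hydrogen-bond donors and acceptors stay the same. Nothing available explains the size of this step.

The change swaps the halogen and alters its printed ring position at once, so the compounds shown leave open which of the two carries the step. As far as these compounds go, on this core, 4-fluorophenyl would separate them, and how a methoxy group or a nitrile on the same ring would read also remains open.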